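Isobutyl to Cyclobutyl on the Amide Nitrogen

The source may report more compounds than this note shows. Statements on the series, on what has been measured and on what is new or still open speak of the compounds shown alone.

Four compounds share one core. Compound 1 `CNC(=O)c1cc(C(=O)NC2CC2)cn(Cc2ccc(OC)cc2)c1=O` and compound 3 `CNC(=O)c1cc(C(=O)NC2CC2)cn(Cc2cccc([C@@H](C)O)c2)c1=O` carry a cyclopropyl on the amide nitrogen, while compound 2 `CNC(=O)c1cc(C(=O)NCC(C)C)cn(Cc2ccccc2)c1=O` carries an isobutyl there. In a physicochemical assay for solubility (a lower number here means a less soluble compound, a higher number a more soluble compound), compound 1 gives >= 143 ug/mL, which is a limit of the assay and not a number. Compound 3 gives >= 131 ug/mL in this assay, also a limit. The step that the two limits leave unreadable from compound 1 to compound 3 is therefore not readable. Two of the three values sit at limits: the limit of >= 143 ug/mL in this assay, at which 1 of the 3 values shown sits, and (the limit of >= 131 ug/mL in this assay, at which 1 of the 3 values shown sits). For the measured compounds named here, compound 2 gives 43 ug/mL in this assay, the only plain number among the three values shown.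

Compound 4 `CNC(=O)c1cc(C(=O)NC2CCC2)cn(Cc2ccccc2)c1=O` has not yet been measured. It differs from compound 2 by cyclobutyl in place of isobutyl on an amide-type nitrogen. Going by the values given here, no measured step covers this exchange: the single comparison available, from compound 1 to compound 3, concerns a different part of the molecule and cannot be read in size. With nothing measured to point either way, the expected step is a 1.2-fold higher number from compound 2 to compound 4 (0.07 log units; within the scatter). Compound 4 is estimated at 50 ug/mL, in a range from 20 ug/mL to 130 ug/mL.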

Compound 4, solubility: 28 ug/mL
Compound 4: middle estimate off by 1.8-fold (0.25 log units), on the high side; measured number inside the range.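

For the compounds shown here, on an amide-type nitrogen, cyclobutyl in place of isobutyl gives a 1.5-fold lower number from compound 2 to compound 4 (0.19 log units; within the scatter) in this assay, and this is the only step so far that can be read in size. The exchange keeps the four heavy atoms and adds no hydrogen-bond donor or acceptor, and for this one pair the ring of four carbons replaces the open chain with a result that stays within the scatter. Nothing measured here offers a cause for this step.

Compounds 1 and 3 carry cyclopropyl on this nitrogen, but they also differ from compound 2 and compound 4 on the other side of the core, so the shown compounds do not place cyclopropyl against these two groups. From the compounds shown here alone, how this nitrogen would read with a chain ending in a tertiary amine or a carboxylic acid also remains open.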